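From Methyl to Acetamido: A Step Still Unmeasured

The source may hold more compounds than are shown below. What is called first, only, known or untested is meant among the compounds shown, and "the series" means these compounds.

In a functional assay on RS4-11 cells (Homo sapiens) for inhibition, read by CCK-8 assay, with a stated time of 48 h, tested at 20 uM (a lower number here means less inhibition of growth, a higher number more inhibition of growth at the concentration tested), compound 2 (`Cc1ccc(S(=O)(=O)Oc2cccc(/C=C(\C#N)C(=O)Nc3nnc(-c4cccs4)s3)c2)cc1`) gives 25%. Among the compounds with values here, its only measured neighbour, compound 1 (`Cc1ccc(S(=O)(=O)Oc2cccc(/C=C(\C#N)C(=O)Nc3nnc(-c4ccccc4)s3)c2)cc1`), gives 35%, so the numbers do not separate these two compounds. Compound 3 (`CC(=O)Nc1ccc(S(=O)(=O)Oc2cccc(/C=C(\C#N)C(=O)Nc3nnc(-c4cccs4)s3)c2)cc1`) is built from compound 2 by one change, acetamido in place of methyl on an aromatic carbon, para to a large group (acetamido in place of methyl on an aromatic carbon). Within the data shown here, the only measured step, a number 10 percentage points lower from compound 1 to compound 2 (within the scatter), has thiophen-2-yl in place of phenyl. It therefore concerns a different place in the molecule and says nothing directly about the new group. What it does show is that one swap on these compounds has so far stayed within the usual scatter of this assay. Among the measured compounds shown here, no measured compound carries acetamido, so the data give no direction for this change, and the expectation is no step beyond the scatter. The estimate is a number 3 percentage points higher from compound 2 to compound 3 (within the scatter). For compound 3, the expected growth inhibition is 28%, with an estimated range from 12% to 46%.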

Compound 3, percent growth inhibition at one concentration: 33%
Compound 3: the middle estimate sits 5 percentage points below what was measured, and the stated range covers the measured number.
By their numbers in this assay, from the lowest: compounds 2, 3 and 1 (each within the scatter of the next).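

In this assay, the aromatic carbon para to a large group can now be read for the first time among these compounds, and acetamido in place of methyl gives a number 8 percentage points higher from compound 2 to compound 3 (within the scatter). The earlier step changed a different place in the molecule, so it could not show that this position tolerates acetamido, with 4 heavy atoms against 1 for methyl and with a hydrogen-bond donor and a hydrogen-bond acceptor that methyl lacks, without a change in growth inhibition beyond the scatter. No supporting measurement accompanies this result to explain why the swap leaves the number within the scatter.

This single swap does not settle whether other groups at the same position would also stay within the scatter, such as an amine, a carboxylic acid or a longer chain in place of methyl. Among the compounds shown, acetamido also appears only with thiophen-2-yl, so whether it would give a similar result alongside phenyl remains open.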